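The source may report more compounds than this note shows. Statements on the series, on what has been measured and on what is new or still open speak of the compounds shown alone.

Working notes on the series. Within the data shown here, compound 1 `CCO[C@@]1(CC)CCC2(CO1)[C@@H]1CCC3=C4[C@@H](CC3=O)[C@H](C(=O)OC)C[C@@]42CN(C)C1` and compound 2 `CCC1=CCC2(CO1)[C@@H]1CCC3=C4[C@H](CC3=O)[C@H](C(=O)OC)C[C@@]42CN(C)C1` are the two compounds measured so far. In a functional assay on HL-60 cells (Homo sapiens) for cytotoxicity, read by MTT assay, with a stated time of 48 h (a lower number here means a stronger inhibitor, a higher number a weaker inhibitor), compound 1 gives > 40000 nM, which is a limit of the assay and not a number. In this assay compound 2 gives > 40000 nM, also a limit rather than a number. Where compound 2 stands is therefore known only as a limit; the other value shown sits at the same limit, as the limit of > 40000 nM in this assay, at which 2 of the 2 values shown sit, records. Compound 3 `COC(=O)[C@@H]1C[C@@]23CN(C)C[C@@H](CCC4=C2[C@@H]1CC4=O)C31CC=C(C(C)C)OC1` is not yet measured and differs from compound 2 by methyl in place of hydrogen on a saturated chain carbon bound to a double-bonded ring carbon and a saturated chain carbon. Among the measured compounds shown here, no step between measured compounds exists in this set, so no measured direction can be pointed to. The step of a number no higher from compound 2 to compound 3 (the limit leaves the size open) is expected to lie within the usual scatter, with no movement beyond it. Compound 3 is expected to give 40000 nM, in the range 20000 nM to 80000 nM, most likely reported again only as a limit.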

Compound 3, half-maximal inhibitory concentration: > 40000 nM
Compound 3: no number, only a limit (the forecaster's own chance of this, stated with the estimate: 75%); the middle value lies on the limit itself.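

Among these compounds, with compound 2 and compound 3 each known only as a limit, no step between them can be read. The compounds shown leave open how strongly any of them acts, and whether ethyl or isopropyl makes any difference: the limit of > 40000 nM in this assay, at which 3 of the 3 values shown sit.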